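Replacing the thiazolyl sulfonamide of compound 2 with bromophenyl

This account rests on a few compounds, and the source may have more. Where it says the series, first, only, none or still open, it means among the compounds named here.

Going by the values given here, the series so far holds two measured compounds. In a functional assay on DLD-1 cells (Homo sapiens) for antiproliferative activity, read by CellTiter-Glo, with a stated time of 72 h (on this read-out lower numbers stand for stronger inhibition and higher numbers for weaker inhibition), compound 1, `CC1CCN(C2CCN(S(=O)(=O)c3ccc(Br)cc3OC(F)(F)F)CC2)CC1`, gives 5 nM. Compound 2, `CC1CCN(C2CCN(S(=O)(=O)c3cnc(Cl)s3)CC2)CC1`, stands at the highest of the two numbers, with 1800 nM in this assay, far apart from compound 1 and well beyond the scatter. Compound 3, `CC1CCN(C2CCN(S(=O)(=O)c3cccc(Br)c3)CC2)CC1`, has not been measured yet. Compared with compound 2 it carries 3-bromophenyl in place of 2-chloro-1,3-thiazol-5-yl on a sulfonyl sulfur; the change sits on a sulfonyl sulfur whose other neighbour is a sulfonamide nitrogen in a ring. Among the compounds with values here, no measured pair differs in exactly this way, so the expectation rests on what the two values show. For compound 3 the expected step in this assay is a large one downward, a 30-fold lower number from compound 2 to compound 3 (1.48 log units; beyond the scatter), because compound 1 gives 5 nM and thereby shows that this read-out can fall far beneath the number of compound 2. Compound 3 is estimated at 60 nM, within a range from 10 nM to 400 nM.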

Compound 3, half-maximal inhibitory concentration: 3.2 nM
Compound 3: middle estimate off by 19-fold (1.27 log units), on the high side, and the stated range ends above it.
By their numbers in this assay, from the lowest: compounds 3 and 1 (each within the scatter of the next); then compound 2.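

In this assay, going by these compounds alone, putting 3-bromophenyl in place of 2-chloro-1,3-thiazol-5-yl on a sulfonyl sulfur gives a 560-fold lower number from compound 2 to compound 3 (2.75 log units; beyond the scatter), the first step that differs in one place, so the group on this sulfur alone, with the rest of the structure unchanged, can shift the number by a large amount. The change replaces the ring, the halogen and the hetero atoms all at once, so this single step cannot say which of them matters. No measured finding here explains the size of the step.

Going by these compounds, what this assay would show for an unsubstituted phenyl group on this sulfur remains open, which leaves the contribution of the bromine undefined. Equally open, on these data alone, is whether chlorine, a methoxy group, a nitrile or an amine could take the place of that bromine.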